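The compounds below may be only part of what the source reports. "The series", "measured", "known", "first", "only" and "open" are said of these compounds alone.

Compound 1 `CC(C)C[C@H]1C[C@@H](Cl)CCO1`: > 100000 nM
Compound 2 `Cl[C@H]1CCO[C@@H](c2ccccc2)C1`: > 100000 nM

In a functional assay on A2780 cells (Homo sapiens) for antiproliferative activity (on this read-out higher numbers stand for weaker inhibition of growth and lower numbers for stronger inhibition of growth), compound 1 gives > 100000 nM, which is a limit of the assay and not a number. In this assay compound 2 gives > 100000 nM, likewise a limit of the assay rather than a measured number. Compound 2 therefore stands at the limit of > 100000 nM in this assay, at which 2 of the 2 values shown sit, so nothing separates it from the other measured compound. Compound 3 `O=[N+]([O-])c1ccc([C@H]2C[C@@H](Cl)CCO2)cc1` has not yet been measured. It differs from compound 2 by nitro in place of hydrogen on an aromatic carbon. For the measured compounds named here, no measured pair shows what such a change does in this assay, and with both measured values at the limit there is no scale on which to read a step. The expectation is that compound 3 also sits at or near the limit, with a step of a number no higher from compound 2 to compound 3 (the limit leaves the size open) of no clear size in either direction. Compound 3 is estimated at 100000 nM, with a range from 30000 nM to 300000 nM.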

Compound 3, concentration for 50% growth inhibition: > 100000 nM
Compound 3 ended at the assay's limit; the forecaster's own chance of this, stated with the estimate: 80%; the middle value lies on the limit itself.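

Compound 2 and compound 3 both sit at a limit of this assay and not at a number, so the step between them cannot be read: the limit of > 100000 nM in this assay, at which 3 of the 3 values shown sit. The compounds shown leave open whether any change to the shared core brings growth inhibition into the measurable range.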